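Notes on replacing fluoro with trifluoromethoxy in the series

The source may report more compounds than this note shows. Statements on the series, on what has been measured and on what is new or still open speak of the compounds shown alone.

Values measured so far in a functional assay on NCI-H460 cells (Homo sapiens) for inhibition, read by MTT assay, with a stated time of 24 h, tested at 1 ug/mL; a lower number here means less inhibition of growth, a higher number more inhibition of growth at the concentration tested
compound 1 `O=C(CCCCC(S)CCS)Nc1ccccc1` gives 4.3%
compound 2 `O=C(CCCCC(S)CCS)Nc1ccc(Cl)cc1` gives 6.76%
compound 3 `O=C(CCCCC(S)CCS)Nc1ccc(F)cc1` gives 6.84%

Compound 3, at 6.84%, stands within the scatter of both other measured compounds. The gaps are small: a number 2.5 percentage points higher from compound 1 to compound 3 (within the scatter) and a number 0.1 percentage points higher from compound 2 to compound 3 (within the scatter). The next compound is compound 4 `O=C(CCCCC(S)CCS)Nc1ccc(OC(F)(F)F)cc1`, not yet measured. It carries trifluoromethoxy in place of fluoro on an aromatic carbon, para to a large group, and the change counts as trifluoromethoxy in place of fluoro on an aromatic carbon.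

Going by the values given here, three measured steps bear on this change, all at the same place on the ring. Two of them put a halogen in place of hydrogen, a number 2.5 percentage points higher from compound 1 to compound 2 (within the scatter) and a number 2.5 percentage points higher from compound 1 to compound 3 (within the scatter), and the third swaps one halogen for the other, a number 0.1 percentage points higher from compound 2 to compound 3 (within the scatter). None of them goes beyond the scatter, so this place has shown no sensitivity so far in this assay. Among the compounds with values here, no measured compound carries trifluoromethoxy, however, which leaves the range wide on the upper side. The expected change is no step beyond the scatter, estimated as a number 1.2 percentage points higher from compound 3 to compound 4 (within the scatter). The estimate for compound 4 is 8%. The expected range for compound 4 runs from 2% to 18%.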

Compound 4, percent growth inhibition at one concentration: 19.1%
Beside the measured number, compound 4's estimate is 11.1 percentage points below it; measured number outside the range, above it.
By their numbers in this assay, from the lowest: compounds 1, 2 and 3 (each within the scatter of the next); then compound 4.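

In this assay, the place on the aromatic carbon, para to a large group, proves able to respond after all: the trifluoromethoxy compound shows a number 12.3 percentage points higher from compound 3 to compound 4 (beyond the scatter) and a number 12.3 percentage points higher from compound 2 to compound 4 (beyond the scatter) and a number 14.8 percentage points higher from compound 1 to compound 4 (beyond the scatter) with all three steps of modest size. The flat picture from chloro and fluoro therefore holds for those two halogens only and does not describe the place as a whole, and compound 4 now stands apart from the other three compounds at the concentration tested. Nothing at hand explains what in the trifluoromethoxy group lies behind this step.

The compounds shown leave open whether the step belongs to trifluoromethoxy alone or would also appear with a methoxy, trifluoromethyl or carboxylic acid group at the same place, since only one group so far stands apart from the rest. They also leave open whether the same change would give a step of similar size on a different chain or at another place on the ring, as all four compounds share one core and one substitution place.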